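The compounds below may be only part of what the source reports. "The series", "measured", "known", "first", "only" and "open" are said of these compounds alone.

Three compounds sharing one core have been examined in a functional assay on HeLa cells (Homo sapiens) for antiproliferative activity, read by CCK-8 assay, with a stated time of 72 h, tested at 2 uM; on this read-out higher numbers stand for a stronger effect at the one concentration tested and lower numbers for a weaker effect. Compound 1, `Nc1ccccc1NC(=O)c1ccc(CSC(=S)N2CCN(Cc3ccccn3)CC2)cc1`, gives 14.2% in this assay. Compound 2, `Nc1ccccc1NC(=O)c1ccc(CSC(=S)N2CCc3ccc([N+](=O)[O-])cc32)cc1`, gives 45.7%, and compound 3, `CC1CCN(C(=S)SCc2ccc(C(=O)Nc3ccccc3N)cc2)CC1`, gives 46.8%. Among these three numbers compound 1 stands lowest; the nearest to it is compound 2, whose number is higher by a margin beyond the usual scatter, and the furthest is compound 3, whose number is higher by a slightly larger margin, also beyond the scatter.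

The next compound, compound 4, is `Nc1ccccc1NC(=O)c1ccc(CSC(=S)N2CCN(c3cnccn3)CC2)cc1`. It differs from compound 1 in one place: pyrazin-2-yl in place of (pyridin-2-yl)methyl on an amine nitrogen in a ring. Among the compounds with values here, no pair of measured compounds shows this particular change, so its effect cannot be read from the data. On the numbers shown, the direction in this assay is open; compound 4 is expected to give 25%, with a range from 8% to 45%, a step of a number 10.8 percentage points higher from compound 1 to compound 4 (beyond the scatter) that is estimated to lie mostly within the scatter.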

Compound 4, a percentage reported as inhibition, at one concentration (the size of the read-out at that concentration, not a potency): 70.4%
For compound 4 the middle estimate is 45.4 percentage points below the measured one, outside the stated range (above it).
By their numbers in this assay, from the lowest: compound 1; then compounds 2 and 3 (each within the scatter of the next); then compound 4.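

At the amine nitrogen in the six-membered non-aromatic ring with 2 nitrogen, the substituent has a strong bearing on the result in this assay: pyrazin-2-yl in place of (pyridin-2-yl)methyl gives a number 56.2 percentage points higher from compound 1 to compound 4 (beyond the scatter). Within the data shown here, the earlier compounds offered no pair differing in one place, so this is the first change on the shared core whose effect can be read directly. No measurement at hand accounts for the size of this step.

The change replaces the aromatic ring and removes the methyl link in a single step, so the compounds shown cannot separate the two. A pyridin-2-yl group attached directly to that nitrogen, or a (pyrazin-2-yl)methyl group, would tell these two parts of the change apart.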